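Acyclic thymine analogues and tolerance of Vero cells

This account rests on a few compounds, and the source may have more. Where it says the series, first, only, none or still open, it means among the compounds named here.

Compound 1 `Cc1cn(COC(CO)CO)c(=O)[nH]c1=O` reaches only the limit > 434000 nM in a functional assay on Vero cells (Chlorocebus sabaeus) for cytotoxicity; a lower number here means that less compound is tolerated, a higher number that more compound is tolerated. Compound 2 `O=c1[nH]c(=O)n(COC(CO)CO)cc1CO` likewise reaches only the limit > 406000 nM in this assay. Compound 3 `O=c1[nH]c(=O)n(COC(CO)CO)cc1CCO` again reaches only the limit > 384000 nM in this assay.

Compound 3 therefore stands at a limit, and so do the two other compounds: none of the three gives a number. The three steps between them are accordingly unreadable: a step that the two limits leave unreadable from compound 1 to compound 2, a step that the two limits leave unreadable from compound 1 to compound 3 and a step that the two limits leave unreadable from compound 2 to compound 3, because of the limit of > 384000 nM in this assay, at which 1 of the 3 values shown sits, the limit of > 406000 nM in this assay, at which 1 of the 3 values shown sits, and the limit of > 434000 nM in this assay, at which 1 of the 3 values shown sits, each cap one of the values.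

Compound 4 `O=c1[nH]c(=O)n(COC(CO)CO)cc1/C=C/Br` differs from compound 3 in one place: 2-bromoethenyl in place of 2-hydroxyethyl on an aromatic carbon. Going by the values given here, no measured step bears on this change, since every step among compounds 1, 2 and 3 is masked by its limits; what the three compounds do show is that the core with the hydroxy-bearing side chain is tolerated up to the concentrations tested. With nothing pointing either way, no step beyond the scatter is expected, so the step from compound 3 to compound 4 in this assay is estimated as an at least 1.2-fold lower number from compound 3 to compound 4 (0.10 log units; that floor lies within the scatter).

Compound 4 is thus expected to give about 300000 nM in this assay, with a range from 80000 nM to 500000 nM, and a limit rather than a number remains the likelier outcome.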

Compound 4, half-maximal cytotoxic concentration: > 311000 nM
Compound 4 gave a limit, no number; the forecaster's own chance of this, stated with the estimate: 65%; middle value at least 1.0-fold (0.01 log units) from the limit.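

With compound 4 also standing only at a limit, the steps linking it to compound 1, compound 2 and compound 3 in this assay cannot be read: the limit of > 311000 nM in this assay, at which 1 of the 4 values shown sits.

The compounds shown leave open at what concentration, if any, each of the four becomes toxic to the cells, and so whether methyl, hydroxymethyl, 2-hydroxyethyl and 2-bromoethenyl differ at all in this assay.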